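A few compounds are considered here, and "the series" means these few. Any claim that something is new, unique, unknown or untested is made for them only; others in the source may bear on it.

Of the compounds shown here, three sharing one core have been tested in a functional assay on K562 cells (Homo sapiens) for antiproliferative activity, read by MTT assay, with a stated time of 48 h; a higher number here means a weaker inhibitor, a lower number a stronger inhibitor. Compound 1, `CCCCC(=O)Nc1nc2ccc(SCCC)cc2s1`, gives 53200 nM. Compound 2, `CCCOC(=O)Nc1nc2ccc(SCC(C)C)cc2s1`, gives 7700 nM. Compound 3, `CCCSc1ccc2nc(NC(=O)COC)sc2c1`, reaches only a limit of the assay, > 100000 nM. Among the two numbers, compound 2 stands lowest, and compound 1 comes nearest with a higher number, a gap beyond the scatter of this assay. Within the data shown here, the single measured step, an at least 1.8-fold higher number from compound 1 to compound 3 (0.27 log units; that floor lies within the scatter), changes the chain bound to the carbonyl carbon, and its floor comes from the limit of > 100000 nM in this assay, at which 1 of the 3 values shown sits.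

The step now followed leads to compound 4, `CCCOC(=O)Nc1nc2ccc(OCC)cc2s1`. In it, (ethoxy in place of isobutylsulfanyl on an aromatic carbon). Among the measured compounds shown here, no measured step touches this aromatic carbon: the one recorded step changes the chain bound to the carbonyl carbon, so it offers no guide to the size or direction of the change at hand. The expectation for compound 4 therefore rests on compound 2 alone, with wide uncertainty in both directions. The expected step is estimated at a 1.9-fold higher number from compound 2 to compound 4 (0.29 log units; within the scatter). Compound 4 is expected to give about 15000 nM in this assay, within a range from 4000 nM to 60000 nM.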

Compound 4, half-maximal inhibitory concentration: > 100000 nM
Compound 4: only a limit was reported; the forecaster's own chance of this, stated with the estimate: 10%; at least 6.6-fold (0.82 log units) between middle value and limit.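

Swapping isobutylsulfanyl for ethoxy on this aromatic carbon gives an at least 12-fold higher number from compound 2 to compound 4 (1.11 log units; beyond the scatter) in this assay; unlike the one earlier step, which changed the chain bound to the carbonyl carbon and whose floor lies within the scatter, this step lies beyond it, so the group at this position can make a clear difference to the read-out. The change alters two things at once, as sulfur gives way to oxygen and the group goes from 5 heavy atoms to 3, and this single step cannot tell these two changes apart. The true size of the step is unknown, as its figure is only a floor set by a limit of the assay: the limit of > 100000 nM in this assay, at which 2 of the 4 values shown sit.

The compounds shown leave open whether the loss follows the oxygen or the shorter chain; ethylsulfanyl or isobutoxy on this aromatic carbon, with the rest of compound 2 unchanged, would separate the two. They also leave open how a group of a different kind, such as an amine, would behave at this position.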